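Swapping a Thioether Link for a Benzylamine

The compounds below may be only part of what the source reports. "The series", "measured", "known", "first", "only" and "open" are said of these compounds alone.

Compound 1 `Nc1cc(N)c2nc(-c3ccccc3)c(Sc3ccc(F)cc3)nc2c1` gives 50100 nM in a functional assay on SW-620 cells (Homo sapiens) for inhibition, read by sulforhodamine B assay, with a stated time of 48 h; a higher number here means a weaker inhibitor of growth, a lower number a stronger inhibitor of growth.
Compound 2 `COc1cc(CNc2nc3cc(N)cc(N)c3nc2-c2ccccc2)cc(OC)c1OC` gives 4470 nM in this assay.
Compound 3 `CCOC(=O)[C@H](CCC(=O)O)NC(=O)c1ccc(CNc2nc3cc(N)cc(N)c3nc2-c2ccccc2)cc1` reaches only a limit, < 100000 nM, in this assay.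

Of the two numbers in hand, compound 1 stands highest, so it is the weaker growth inhibitor, and compound 2 sits well beneath it, a gap beyond the usual scatter. Compound 3 is known only by its limit of < 100000 nM in this assay, at which 1 of the 3 values shown sits, and adds no number.

Compound 4 `Nc1cc(N)c2nc(-c3ccccc3)c(NCc3ccc(F)cc3)nc2c1` is not yet measured. It differs from compound 1 in one place: (4-fluorobenzyl)amino in place of (4-fluorophenyl)sulfanyl on an aromatic carbon. Compound 2 also carries a benzylamino link on the shared core, and it gives 4470 nM.

The step of a 3.3-fold lower number from compound 1 to compound 4 (0.52 log units; beyond the scatter) is expected to be a fall beyond the scatter. Compound 4 is expected to give about 15000 nM, within 4000 nM to 50000 nM.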

Compound 4, concentration for total growth inhibition: 9550 nM
For compound 4 the middle estimate is 1.6-fold (0.20 log units) above the measured one; the range from low to high includes it.
By their numbers in this assay, from the lowest: compound 2; then compound 4; then compound 1.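

On the shared core, this position responds to the linking group: in this assay, putting (4-fluorobenzyl)amino in place of (4-fluorophenyl)sulfanyl gives a 5.2-fold lower number from compound 1 to compound 4 (0.72 log units; beyond the scatter), a modest step. The entering group carries a hydrogen-bond donor that the leaving group lacks and has a longer link to its ring, so this single step cannot separate those two changes. Nothing measured here explains why the number falls.

Still open, from the compounds shown here alone, is how this position would respond to an ether link, or to a longer chain ending in a carboxylic acid.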